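A few compounds are considered here, and "the series" means these few. Any claim that something is new, unique, unknown or untested is made for them only; others in the source may bear on it.

Measured compounds in an assay on isolated protein for inhibition of malate dehydrogenase, mitochondrial (Sus scrofa), with stated times of 45 min and 30 min; on this read-out higher numbers stand for weaker inhibition and lower numbers for stronger inhibition:
Compound 1 `O=S(=O)(Nc1ccc(-c2nc3ccccc3o2)cc1)c1cccc(F)c1` gives > 63000 nM, a limit of the assay.
Compound 2 `O=S(=O)(Nc1ccc(-c2nc3ccccc3o2)cc1)c1ccc(Cl)s1` gives > 63000 nM, a limit of the assay.
Compound 3 `O=S(=O)(Nc1ccc(-c2nc3ccccc3o2)cc1)c1ccccc1Cl` gives > 63000 nM, a limit of the assay.

Compound 3 therefore stands at a limit, and the two other values shown are limits as well, so no measured value places it above or below its neighbours. The steps a step that the two limits leave unreadable from compound 1 to compound 3, a step that the two limits leave unreadable from compound 2 to compound 3 and a step that the two limits leave unreadable from compound 1 to compound 2 are all unreadable because the limit of > 63000 nM in this assay, at which 3 of the 3 values shown sit, hides any difference between them.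

Compound 4 `O=S(=O)(Nc1ccc(-c2nc3ccccc3o2)cc1)c1cccc(O)c1` is the next compound; it is not yet measured. Its change from compound 3 is 3-hydroxyphenyl in place of 2-chlorophenyl on a sulfonyl sulfur. Going by the values given here, every measured step on the sulfonyl sulfur bears on it, yet none gives a size, so the only guide is that three different groups in that place all left the read-out at the limit. Compound 4 is thus expected to show no readable step beyond the scatter, a step that the limit leaves unreadable from compound 3 to compound 4, and most likely to remain at the limit. The estimate for compound 4 in this assay is 80000 nM, within a range from 20000 nM to 300000 nM.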

Compound 4, half-maximal inhibitory concentration: > 63000 nM
Compound 4: no number, only a limit; the forecaster's own chance of this, stated with the estimate: 80%; the middle value does not contradict the limit.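

The steps from compound 1, compound 2 and compound 3 to compound 4 cannot be read, because all four compounds share the same limit: the limit of > 63000 nM in this assay, at which 4 of the 4 values shown sit. The compounds shown leave open how these four rank in this assay and whether any group on the sulfonyl sulfur of the shared core would give a measured number there.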